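Adding a third methoxy group to the aryl ring of compound 3

This account rests on a few compounds, and the source may have more. Where it says the series, first, only, none or still open, it means among the compounds named here.

Compound 1 `COc1cc(/C=C/C2CC(=O)C=CO2)cc(OC)c1OC`: 135 uM
Compound 2 `COc1ccc(/C=C/C2CC=CC(=O)O2)cc1OC`: 17.2 uM
Compound 3 `COc1cc(/C=C/C2CC=CC(=O)O2)cc(OC)c1`: 8.2 uM

Three styryl lactones have been measured in a functional assay on HT-29 cells (Homo sapiens) for inhibition, read by sulforhodamine B assay, with a stated time of 48 h; a higher number here means a weaker inhibitor of growth, a lower number a stronger inhibitor of growth. Compound 3 gives the lowest number of the three; compound 2 sits nearest to it, at a gap that lies beyond the scatter, and compound 1 is furthest away, also beyond the scatter. Compound 3 is therefore the strongest growth inhibitor of the measured set. Compound 1 carries a trimethoxy-substituted aryl ring but a different lactone core, and it gives by far the weakest growth inhibition here.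

Compound 4 `COc1cc(/C=C/C2CC=CC(=O)O2)cc(OC)c1OC` has not yet been measured. It keeps the lactone core of compound 3 and differs from it in one place: methoxy in place of hydrogen on an aromatic carbon. Compound 4 thus carries the same trimethoxy aryl pattern as compound 1, joined to the core of compound 3.

For the measured compounds named here, no measured pair shows this exact change on this core. Because compound 1 gives 135 uM while compound 3 gives 8.2 uM, the expectation for compound 4 is a modest step toward a higher number, a 1.7-fold higher number from compound 3 to compound 4 (0.23 log units; within the scatter), with wide uncertainty. Compound 4 is estimated at 14 uM, in a range from 4 uM to 45 uM.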

Compound 4, concentration for growth inhibition (reported as GI): 18.8 uM
Compound 4: middle estimate off by 1.3-fold (0.13 log units), on the low side; measured number inside the range.
By their numbers in this assay, from the lowest: compound 3; then compounds 2 and 4 (each within the scatter of the next); then compound 1.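

In this assay, placing methoxy on the aromatic carbon ortho to two methoxy groups and para to the group of 9 heavy atoms gives a 2.3-fold higher number from compound 3 to compound 4 (0.36 log units; beyond the scatter), so on this core the position accepts the group at a modest loss of growth inhibition, a change that no earlier pair had shown. The same kind of replacement starting from the other dimethoxy ring gives a 1.1-fold higher number from compound 2 to compound 4 (0.04 log units; within the scatter), a step within the scatter, so the effect of completing the trimethoxy pattern depends on which aromatic carbon receives the new methoxy. With the trimethoxy ring held constant, exchanging one core for the other gives a 7.2-fold lower number from compound 1 to compound 4 (0.86 log units; beyond the scatter), a larger step than either methoxy step, which places the core ahead of the third methoxy as the bigger influence among these compounds.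

As far as these compounds go, it remains open whether a hydroxyl, an amine or a longer alkoxy chain on this same aromatic carbon would keep growth inhibition as close to that of compound 3, and whether methoxy there has the same effect on the core of compound 1. Nothing shown here accounts for the size of any of these steps.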